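The compounds below may be only part of what the source reports. "The series", "measured", "known", "first", "only" and "open" are said of these compounds alone.

Measured compounds in an assay on microsomes from intestine for inhibition of acyl-CoA:cholesterol acyltransferase (Oryctolagus cuniculus); a higher number here means a weaker inhibitor, a lower number a stronger inhibitor:
compound 1, `CCCCCCCCCCOC(=O)NC(=O)Oc1c(C(C)C)cccc1C(C)C`, gives 74 nM;
compound 2, `CCCCCCCCCCCCOC(=O)NC(=O)Oc1c(C(C)C)cccc1C(C)C`, gives 21 nM;
compound 3, `CCCCCCCCCCCCC(C)OC(=O)NC(=O)Oc1c(C(C)C)cccc1C(C)C`, gives 17 nM.

Among the compounds with values here, the one step between measured compounds that differ in a single place is a 3.5-fold lower number from compound 1 to compound 2 (0.55 log units; beyond the scatter), and the change behind it is ethyl in place of hydrogen on a saturated chain carbon, ten or more bonds along the chain from an oxygen next to a carbonyl group. Compound 3 stands at the lowest number of the three; against compound 2 the gap is within the scatter, so the two cannot be ordered, while against compound 1 it lies beyond the scatter. How compound 3 differs from compound 1 is not broken down here.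

Compound 4, `CCCCCCCCCCCCCCC(C)OC(=O)NC(=O)Oc1c(C(C)C)cccc1C(C)C`, has not yet been measured in this assay. It differs from compound 3 by ethyl in place of hydrogen on a saturated chain carbon, ten or more bonds along the chain from an oxygen next to a carbonyl group, which is the same change as from compound 1 to compound 2, at a place described in the same words. In this assay the expected step is a 1.5-fold lower number from compound 3 to compound 4 (0.19 log units; within the scatter), smaller than the earlier one because a 3.5-fold lower number from compound 1 to compound 2 (0.55 log units; beyond the scatter) started from a shorter chain, whereas the chain of compound 3 is already longer and the gap between compound 2 and compound 3 is within the scatter. Compound 4 is therefore estimated at 11 nM, with a range from 5 nM to 28 nM.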

Compound 4, half-maximal inhibitory concentration: 58 nM
The estimate for compound 4 lay 5.3-fold (0.72 log units) below the measured number, outside the stated range (above it).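

In this assay, the replacement of hydrogen by ethyl on the saturated chain did not carry over from one core to the other. It gave a 3.4-fold higher number from compound 3 to compound 4 (0.53 log units; beyond the scatter), and this step runs opposite to the earlier one: the same change on two cores in this assay, a 3.5-fold lower number (0.55 log units; beyond the scatter) from compound 1 to compound 2 and a 3.4-fold higher number (0.53 log units; beyond the scatter) from compound 3 to compound 4, 12-fold (1.08 log units) apart, beyond the scatter of two such steps The outcome of this change in the series therefore depends on the core that receives it, and the drop in the number seen on the core of compound 1 cannot be assumed for another core. Within the data shown here, with only two pairs, this shows no general rule, and it neither explains the reversal nor identifies the chain at which the direction turns.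

The compounds shown leave open whether a longer chain than that of compound 4 would raise the number further, and what the same change would do on the core of compound 2. They also leave open how an amine or a carboxylic acid on the chain would compare with the plain carbon chains.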